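The source may hold more compounds than are shown below. What is called first, only, known or untested is meant among the compounds shown, and "the series" means these compounds.

Compound 1 `Nc1ncnc2c1nc(NCc1cccc(-c3ccccc3)c1)n2[C@@H]1O[C@H](CO)[C@@H](O)[C@H]1O` gives 21000 nM in an assay on COS-7 cells for inhibition of sodium/nucleoside cotransporter 2 (Homo sapiens), read by scintillation counting, in the presence of a further agent that is not named here; a lower number here means a stronger inhibitor, a higher number a weaker inhibitor.
Compound 2 `Nc1ncnc2c1ncn2[C@@H]1O[C@H](COC(=O)NCc2ccccc2)[C@@H](O)[C@H]1O` gives > 100000 nM in this assay, which is a limit of the assay and not a number.
Compound 3 `CCCCCC(=O)OC[C@H]1O[C@@H](n2cnc3c(N)ncnc32)[C@H](O)[C@@H]1O` gives > 100000 nM in this assay, again a limit rather than a number.

Among the measured compounds shown here, compound 1 therefore holds the only measured number among the three compounds; the other two sit at the assay limit, as recorded in the limit of > 100000 nM in this assay, at which 2 of the 3 values shown sit. For the measured compounds named here, the single step that joins two measured compounds, a step that the two limits leave unreadable from compound 2 to compound 3, runs between two limits, so its size cannot be read. Compound 4 `Cc1cccc(CNc2nc3c(N)ncnc3n2[C@@H]2O[C@H](CO)[C@@H](O)[C@H]2O)c1` differs from compound 1 in one place: methyl in place of phenyl on an aromatic carbon. Going by the values given here, no measured step touches that part of the structure, so nothing among the measured compounds says how large a step in this assay to expect, or in which direction. Starting from the one number available, the inhibition of compound 1 at 21000 nM, the estimate for compound 4 is 35000 nM, within a range from 10000 nM to 130000 nM. This estimate means a step of a 1.7-fold higher number from compound 1 to compound 4 (0.22 log units; within the scatter), expected to stay within the usual scatter of the assay, with a real chance that only a limit and no number is reported.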

Compound 4, half-maximal inhibitory concentration: 19000 nM
Beside the measured number, compound 4's estimate is 1.8-fold (0.27 log units) above it; low and high end bracket the measured number.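

Putting methyl in place of phenyl gives a 1.1-fold lower number from compound 1 to compound 4 (0.04 log units; within the scatter) in this assay. Among the compounds shown here, this is the first step that joins two real numbers, and it shows that at this place, on an aromatic carbon meta to a large group, a whole six-membered aromatic ring of carbon can go and leave only a methyl with no readable change in the result. The phenyl is therefore not needed to keep the inhibition at the level of compound 1, although nothing shown here bears on why the two groups read alike.

Methyl and phenyl are both made of carbon alone, so it remains open whether a group with other atoms at this place, such as an amine or a carboxylic acid, would move the number in either direction. Also open, as far as these compounds go, is what a plain hydrogen or a longer chain such as butyl would do here, and whether any group at this place can bring the number clearly below that of these two compounds.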